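Anilino for Methylsulfanyl on a Nucleoside Core

The source may report more compounds than this note shows. Statements on the series, on what has been measured and on what is new or still open speak of the compounds shown alone.

Measured compounds:
compound 1, `CCCCCCNc1[nH]ccc2ncnc1-2`: 100%
compound 2, `[N-]=[N+]=Nc1nccc2ncn([C@H]3C[C@H](O)[C@@H](CO)O3)c12`: < 5%
compound 3, `CSc1nccc2c1ncn2C1O[C@H](CO)[C@@H](O)[C@H]1O`: < 5%

In a functional assay on EL4 cells (Mus musculus) for inhibition, tested at 100 uM (a lower number here means less inhibition, a higher number more inhibition at the concentration tested (going by the name of the read-out)), compound 1 gives 100%. Compound 2 reaches only the limit of this assay, < 5%. Compound 3 likewise stands at the limit of this assay, < 5%, and so its value is not a number but a floor; it sits at the limit of < 5% in this assay, at which 2 of the 3 values shown sit. No pair among these three compounds differs in a single place, so no measured step can be read from them, and the difference between compound 1 and compound 3 can only be noted as what their two values show.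

The step under study leads from compound 3 to compound 4, `OC[C@H]1OC(n2cnc3c(Nc4ccccc4)nccc32)[C@H](O)[C@@H]1O`, which is not yet measured in this assay. The change is anilino in place of methylsulfanyl on an aromatic carbon.

Because compound 3 rests at the limit < 5%, any step from it can only go upward or stay at the limit. The step of a number at least 20 percentage points higher from compound 3 to compound 4 (beyond the scatter) is the expected size and direction, an increase beyond the scatter but far from the top of the scale. Compound 4 is estimated to give 25%, with a range from 3% to 70%.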

Compound 4, a percentage reported as inhibition, at one concentration (the size of the read-out at that concentration, not a potency): 10%
For compound 4 the middle estimate is 15 percentage points above the measured one, and the stated range covers the measured number.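

Anilino in place of methylsulfanyl, on an aromatic carbon next to the ring nitrogen, gives a number at least 5 percentage points higher from compound 3 to compound 4 (that floor lies within the scatter) in this assay, so this change cannot yet be called a real gain. The position does accept the larger group, with its six-membered aromatic ring and its hydrogen-bond donor, and compound 4 gives a value that can be read as a number, 10%, which none of the earlier compounds on this nucleoside-bearing side of the series had shown. Compound 3 remains a limit and not a number, and the step is therefore only a floor, because its starting point rests on that limit: the limit of < 5% in this assay, at which 2 of the 4 values shown sit.

The steps involving compound 1 and compound 2 cannot be read, since each differs from the others in more than one place, and the distance between compound 1 and compound 4 stays unexplained. The compounds shown leave open whether a benzylamino or cyclohexylamino group, or an anilino ring carrying a methoxy group, would on this same core move the read-out beyond the scatter from compound 3.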